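Swapping one amide for an ester at the weak limit

This account rests on a few compounds, and the source may have more. Where it says the series, first, only, none or still open, it means among the compounds named here.

Compounds measured in a functional assay on MCF7 cells (Homo sapiens), read by MTT assay, with a stated time of 48 h; on this read-out higher numbers stand for weaker inhibition and lower numbers for stronger inhibition:
- compound 1 `CCN(CC)CCCNC(=O)c1ccc(C(CC)(CC)c2ccc(OCC(O)C(C)(C)C)c(C)c2)n1CC` gives 190 nM
- compound 2 `C=CCN(C)C(=O)c1ccc(C(CC)(CC)c2ccc(OCC(O)C(C)(C)C)c(C)c2)n1CC` gives > 50000 nM, a limit of the assay and not a number

Compound 2 therefore has no exact value and stands at the limit of > 50000 nM in this assay, at which 1 of the 2 values shown sits. Compound 3 `C#CC(C)OC(=O)c1ccc(C(CC)(CC)c2ccc(OCC(O)C(C)(C)C)c(C)c2)n1CC` has not yet been measured in this assay. It has (1-methylprop-2-yn-1-yl)oxy in place of allyl(methyl)amino on a carbonyl carbon.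

For the measured compounds named here, no measured step makes this exchange. The nearest evidence is an at least 260-fold higher number from compound 1 to compound 2 (2.42 log units; beyond the scatter), a large step beyond the scatter, with allyl(methyl)amino in place of (3-(diethylamino)propyl)amino on the same carbonyl carbon. It rests on a single pair of compounds and shows only how far compound 2 lies from compound 1. Compound 3 lacks (3-(diethylamino)propyl)amino too, and given an at least 260-fold higher number from compound 1 to compound 2 (2.42 log units; beyond the scatter) it is expected to stay far from compound 1, close to the limit, with no step beyond the scatter or only a modest one towards lower numbers. The expected change is an at least 1.6-fold lower number from compound 2 to compound 3 (0.22 log units; that floor lies within the scatter). Compound 3 is estimated at 30000 nM, with an expected range from 6000 nM to 60000 nM.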

Compound 3, half-maximal inhibitory concentration: > 50000 nM
Compound 3: only a limit was reported; the forecaster's own chance of this, stated with the estimate: 55%; middle value at least 1.6-fold (0.22 log units) away from the limit.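

In this assay compound 3 gives > 50000 nM, which is a limit of the assay and not a number. The step from compound 2 to compound 3 cannot be read, so the exchange of allyl(methyl)amino for (1-methylprop-2-yn-1-yl)oxy has no measurable size, and both compounds stand at the same mark: the limit of > 50000 nM in this assay, at which 2 of the 3 values shown sit A second replacement of (3-(diethylamino)propyl)amino on this carbonyl carbon gives an at least 260-fold higher number from compound 1 to compound 3 (2.42 log units; beyond the scatter), so the large loss is not tied to allyl(methyl)amino alone and appears whether nitrogen or oxygen joins the new group to the carbonyl carbon.

The compounds shown do not separate the contributions of the diethylamino group, the propyl chain and the amide hydrogen of compound 1. Going by these compounds, whether a shorter chain ending in dimethylamino, a longer chain ending in diethylamino or a carboxylic acid at this carbonyl carbon would give a value clear of the limit remains open.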